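Swapping One Aryl Group on a Shared Core

This account rests on a few compounds, and the source may have more. Where it says the series, first, only, none or still open, it means among the compounds named here.

Of the compounds shown here, two have been measured, and a third awaits its number. Compound 1 `Cc1cc(OCc2c(-c3cc[nH]c(=O)c3Cl)noc2C(C)C)ccc1-c1ccc2c(C(=O)O)cn(C)c2c1` and compound 2 `COc1ccccc1-c1noc(C(C)C)c1COc1ccc(/C=C/c2cccc(C(=O)O)c2)c(Cl)c1` share much of their structure, including an isopropyl group on the same five-membered ring. In a functional assay for agonist activity at Bile acid receptor (Mus musculus), read by a luciferase reporter (on this read-out lower numbers stand for an effect already at smaller amounts and higher numbers for an effect only at larger amounts of compound), compound 1 gives 7000 nM. In this assay compound 2 gives 10000 nM, the higher of the two numbers, yet its gap to compound 1 falls within the scatter of repeated measurements, so the two cannot be told apart on this evidence.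

Compound 3 `CC(C)c1onc(-c2ccc(S(C)(=O)=O)cc2Cl)c1COc1ccc(/C=C/c2cccc(C(=O)O)c2)c(Cl)c1` is built from compound 2 by a single change: 2-chloro-4-(methylsulfonyl)phenyl in place of 2-methoxyphenyl on an aromatic carbon. Within the data shown here, no measured pair in this small set shows what such a change does, so the size of the step is open. The step of a 6.7-fold lower number from compound 2 to compound 3 (0.82 log units; beyond the scatter) is expected to run toward a lower number and to reach beyond the scatter, although this expectation rests on one starting point and carries wide uncertainty. Compound 3 in this assay is estimated at 1500 nM, with a range from 200 nM to 10000 nM.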

Compound 3, half-maximal effective concentration: > 10000 nM
Compound 3 gave a limit, no number (the forecaster's own chance of this, stated with the estimate: 5%); middle value at least 6.6-fold (0.82 log units) from the limit.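

In this assay compound 3 gives > 10000 nM, which is a limit of the assay and not a number. Among these compounds, this gives the first direct look at this position on the five-membered ring: placing 2-chloro-4-(methylsulfonyl)phenyl there instead of 2-methoxyphenyl gave a number no lower from compound 2 to compound 3 (the limit leaves the size open), so this change brought no measurable gain. How far compound 3 lies from compound 2 cannot be read, and the whole comparison rests on a single value at the edge of what the assay reports: the limit of > 10000 nM in this assay, at which 1 of the 3 values shown sits.

The compounds shown leave open whether any aryl group at this position can bring the number down, for example a phenyl ring carrying an amine, or a plain phenyl ring with no added group. They also leave open which part of the change matters, the chlorine or the methylsulfonyl group, since both enter together and 2-methoxyphenyl leaves in the same step.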